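The source may report more compounds than this note shows. Statements on the series, on what has been measured and on what is new or still open speak of the compounds shown alone.

Compound 1 `COc1cc(-c2nn(-c3ccc(NC(=O)Nc4cc(C(F)(F)F)cc(C(F)(F)F)c4)cc3)cc2-c2ccncc2)ccc1Cl`: 1700 nM
Compound 2 `COc1cc(-c2nn(-c3ccc(NC(=O)c4ccc(Cl)c(Cl)c4)cc3)cc2-c2ccncc2)ccc1Cl`: 5740 nM

In a functional assay on SK-MEL-2 cells (Homo sapiens) for antiproliferative activity, read by sulforhodamine B assay, with a stated time of 48 h (a higher number here means a weaker inhibitor, a lower number a stronger inhibitor), compound 1 gives 1700 nM, the lower of the two numbers; compound 2 gives 5740 nM, a gap that lies beyond the scatter. Compound 3 `O=C(Nc1ccc(-n2cc(-c3ccncc3)c(-c3ccc(Cl)c(O)c3)n2)cc1)Nc1cc(C(F)(F)F)cc(C(F)(F)F)c1` is not yet measured. It differs from compound 1 in one place: hydrogen in place of methyl on an oxygen on an aromatic ring. Nothing measured here shows what this change does, so the expected step in this assay from compound 1 to compound 3 is small, a 1.5-fold higher number from compound 1 to compound 3 (0.17 log units; within the scatter), toward a slightly higher number but possibly within the scatter. The estimate for compound 3 is 2500 nM, with a range from 700 nM to 8000 nM.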

Compound 3, half-maximal inhibitory concentration: 1800 nM
Compound 3: middle estimate off by 1.4-fold (0.14 log units), on the high side, and the stated range covers the measured number.
By their numbers in this assay, from the lowest: compounds 1 and 3 (each within the scatter of the next); then compound 2.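

Taking the methyl off that oxygen, which turns methoxy into hydroxy, gives a 1.1-fold higher number from compound 1 to compound 3 (0.02 log units; within the scatter) in this assay and so leaves the antiproliferative read-out effectively where it stood. Compound 1 and compound 2 differ in more than one place, so they could not show that this oxygen tolerates losing its methyl here. Nothing measured on these compounds accounts for this result. Still open, as far as these compounds go, is how a longer chain on that oxygen, such as ethoxy, would read. An amine in place of the hydroxy is equally untested by the compounds shown.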